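A cytotoxicity limit carried from compound 3 to compound 4

The source may hold more compounds than are shown below. What is called first, only, known or untested is meant among the compounds shown, and "the series" means these compounds.

The account concerns an ADME assay on RAW264.7 cells (Mus musculus) for cytotoxicity, read by MTT assay, with a stated time of 24 h, in the presence of a further agent that is not named here; on this read-out lower numbers stand for stronger inhibition and higher numbers for weaker inhibition. Compound 1 `O=C1OC(Cc2nc(-c3ccccc3)no2)c2ccccc21` gives > 40000 nM in this assay, which is a limit of the assay and not a number. Compound 2 `O=C1OC(Cc2nc(-c3ccc(-c4ccccc4)cc3)no2)c2ccccc21` gives > 40000 nM, again a limit. The step between these two, a step that the two limits leave unreadable from compound 1 to compound 2, cannot be read. Compound 3 `COCCCOc1ccc(C(O)C2OC(=O)c3c(OC)cc(OC)cc32)cc1` gives > 40000 nM, also a limit. Compound 3 therefore stands exactly where every value shown stands, as the limit of > 40000 nM in this assay, at which 3 of the 3 values shown sit, records.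

Compound 4 `COc1cc(OC)c2c(c1)C(C(O)c1ccc(OCc3ccc(OC(F)(F)F)cc3)cc1)OC2=O` differs from compound 3 in one place: 4-(trifluoromethoxy)phenyl in place of 2-methoxyethyl on a saturated chain carbon bound to an oxygen on an aromatic ring. Going by the values given here, no measured step bears on this change; the only step between measured compounds is unreadable, and its two compounds share no such change with compound 4. With every value shown sitting at the limit, no step beyond the scatter is expected in this assay in either direction. The step from compound 3 to compound 4 is accordingly estimated as a step that the limit leaves unreadable from compound 3 to compound 4. Compound 4 is expected to give 60000 nM, within 25000 nM to 200000 nM, and most probably to be reported once more only as a limit.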

Compound 4, half-maximal inhibitory concentration: > 40000 nM
Compound 4 gave a limit, no number; the forecaster's own chance of this, stated with the estimate: 80%; the middle value is on the limit's open side.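

Compound 3 and compound 4 are both reported only as limits, so no new step can be read between them. The compounds shown leave open whether any change of group would give a readable value, since compound 1 to compound 4 all share one result: the limit of > 40000 nM in this assay, at which 4 of the 4 values shown sit.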